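The source may hold more compounds than are shown below. What is called first, only, known or untested is meant among the compounds shown, and "the series" means these compounds.

Of the compounds shown here, two have been measured in a functional assay on COS-7 cells (Chlorocebus aethiops) for inhibition, read by MTT assay; on this read-out lower numbers stand for stronger inhibition and higher numbers for weaker inhibition. Compound 1 `O=C1Nc2ccc(Br)cc2/C1=N/NC(=S)N/N=C/c1ccc(Br)cc1` gives 5180 nM. Compound 2 `Cc1ccc2c(c1)/C(=N/NC(=S)N/N=C/c1ccccn1)C(=O)N2` gives 2120 nM, the lowest of the two numbers, and its gap to compound 1 lies beyond the scatter. Compound 3 `Cc1ccc2c(c1)/C(=N/NC(=S)N/N=C/c1ccc(Br)cc1)C(=O)N2` has not been measured; it carries 4-bromophenyl in place of pyridin-2-yl on a carbon with a double bond to nitrogen. Among the measured compounds shown here, no step between measured compounds shows this change alone, since compound 1 differs from compound 2 in two places, so only a weak expectation is possible. For compound 3 the estimate is 3500 nM, with a range from 1500 nM to 9000 nM. The expected step of a 1.7-fold higher number from compound 2 to compound 3 (0.22 log units; within the scatter) is a modest loss, of a size near the scatter.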

Compound 3, half-maximal inhibitory concentration: > 50000 nM
Compound 3: no number, only a limit; the forecaster's own chance of this, stated with the estimate: 5%; at least 14-fold (1.15 log units) between middle value and limit.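

Compound 3 gives only a limit in this assay, not a number: the limit of > 50000 nM in this assay, at which 1 of the 3 values shown sits. Placing 4-bromophenyl instead of pyridin-2-yl on the carbon with a double bond to nitrogen gives an at least 23-fold higher number from compound 2 to compound 3 (1.37 log units; beyond the scatter), so this position does not accept the exchange without a large loss. Compound 3 also links the earlier pair, since methyl in place of bromo on an aromatic carbon gives an at least 9.6-fold higher number from compound 1 to compound 3 (0.98 log units; beyond the scatter).

Still open, going by these compounds, is whether the loss comes with the ring nitrogen leaving or the bromine entering, which plain phenyl could separate. How a chloro group or a methoxy group would behave at either place is also unknown.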